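Lengthening the Chain Beside the Shared Core

The source may hold more compounds than are shown below. What is called first, only, known or untested is meant among the compounds shown, and "the series" means these compounds.

Compound 2 `CCCn1ncnc1-c1ccccc1NCC1=NCCN1` bears a propyl chain on the aromatic nitrogen of the shared core, and in an in vitro functional assay on cells (Fibroblast) for agonist activity at Alpha-1A adrenergic receptor (Homo sapiens) (a lower number here means that less compound is needed, a higher number that more compound is needed for the effect), compound 2 gives 12.6 nM. Within the data shown here, that is the highest of the two numbers measured so far. Its nearest neighbour is compound 1 `CCn1ncnc1-c1ccccc1NCC1=NCCN1`, which in this assay gives 1.26 nM, so that there is a 10-fold higher number from compound 1 to compound 2 (1.00 log units; beyond the scatter). Compound 3 `CCCCn1ncnc1-c1ccccc1NCC1=NCCN1` continues in the same direction: methyl in place of hydrogen on a saturated chain carbon, three bonds along the chain from an aromatic nitrogen, which read one bond further out is propyl to butyl. Among the measured compounds shown here, the only measured step that bears on this change is the one between compound 1 and compound 2, where the added methyl sat two bonds along the chain from the aromatic nitrogen and produced a 10-fold higher number from compound 1 to compound 2 (1.00 log units; beyond the scatter). On that basis a further rise in this assay is expected for compound 3, although with a single step to lean on its size is uncertain. The expected step is a 3.2-fold higher number from compound 2 to compound 3 (0.50 log units; beyond the scatter). Compound 3 is therefore estimated at 40 nM in this assay, with a range from 12 nM to 160 nM.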

Compound 3, half-maximal effective concentration: 200 nM
The estimate for compound 3 lay 5.0-fold (0.70 log units) below the measured number; measured number outside the range, above it.
By their numbers in this assay, from the lowest: compound 1; then compound 2; then compound 3.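

The added methyl three bonds along the chain from an aromatic nitrogen costs as much as the earlier change, or more: in this assay there is a 16-fold higher number from compound 2 to compound 3 (1.20 log units; beyond the scatter), so the effect of lengthening the chain had not faded at this position, as a single step could not show. Taken together, the propyl to butyl change and the earlier one leave a 160-fold higher number from compound 1 to compound 3 (2.20 log units; beyond the scatter), and across these three compounds the number rises with every lengthening of the chain, with none of them going against that order. No measurement is available that would explain why the number climbs in this way.

The compounds shown leave open whether a longer chain such as pentyl would raise the number further or whether the rise levels off, and whether a methyl on the same aromatic nitrogen would fall below the ethyl of compound 1. They also cannot say whether a chain of similar length carrying a hydroxyl or an amine at its end would follow the same course as the plain butyl chain.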